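This account rests on a few compounds, and the source may have more. Where it says the series, first, only, none or still open, it means among the compounds named here.

Of the compounds shown here, three sharing one core have been measured in a functional assay on HeLa cells (Homo sapiens) for cytotoxicity, read by cell counting, with a stated time of 48 h; on this read-out lower numbers stand for an effect already at smaller amounts and higher numbers for an effect only at larger amounts of compound. Compound 1 `CCCCCCCCCC(=O)O[C@H]1[C@H](O)[C@H](n2ccc(N)nc2=O)O[C@@H]1CO` gives 0.09 ug/mL, the second highest of the three numbers. Compound 3 `CCCCCCCCCC(=O)OC[C@H]1O[C@@H](n2ccc(N)nc2=O)[C@@H](O)[C@@H]1O` gives 0.1 ug/mL, and compound 1 and compound 3 lie within the scatter of each other. Compound 2 `CCCCCCCCCCCCCCCCCCCCCC(=O)OC[C@H]1O[C@@H](n2ccc(N)nc2=O)[C@@H](O)[C@@H]1O` gives 0.04 ug/mL, the lowest of the three numbers. Within the data shown here, the only step between measured compounds that differ in one place is a 2.5-fold higher number from compound 2 to compound 3 (0.40 log units; beyond the scatter): taking away a long piece of a saturated chain raised the number modestly.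

Compound 4 `CCCCCCCCCCCC(=O)O[C@H]1[C@H](O)[C@H](n2ccc(N)nc2=O)O[C@@H]1CO` differs from compound 1 by ethyl in place of hydrogen on a saturated chain carbon, nine bonds along the chain from a carbonyl carbon, a lengthening of the chain on the same kind of chain carbon. The step from compound 2 to compound 3 bears on this, although there a much larger piece of chain was removed. Adding only ethyl is therefore expected to lower the number slightly at most, possibly not beyond the scatter. For compound 4 the expected step is a 1.3-fold lower number from compound 1 to compound 4 (0.11 log units; within the scatter), and the estimate is 0.07 ug/mL, with a range from 0.03 ug/mL to 0.15 ug/mL.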

Compound 4, concentration for half-maximal effect: 0.08 ug/mL
Estimate against measurement, compound 4: 1.1-fold (0.06 log units) below, and the stated range covers the measured number.
By their numbers in this assay, from the lowest: compounds 2, 4, 1 and 3 (each within the scatter of the next, the first and the last beyond it).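

Ethyl in place of hydrogen on a saturated chain carbon, nine bonds along the chain from a carbonyl carbon, gives a 1.1-fold lower number from compound 1 to compound 4 (0.05 log units; within the scatter) and so leaves the number in place. This is the first change shown on the chain as it is attached in compound 1, and it shows that a small lengthening there does not move the number beyond the scatter, whereas the much larger chain difference in the other pair gives a 2.5-fold higher number from compound 2 to compound 3 (0.40 log units; beyond the scatter). Nothing available explains why this small change leaves the number in place.

As far as these compounds go, it remains open whether dodecyl on this same chain carbon would lower the number for the compound 1 type as well. From the compounds shown here alone, it is also open how an amine or a carboxylic acid at this carbon would compare.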